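This account rests on a few compounds, and the source may have more. Where it says the series, first, only, none or still open, it means among the compounds named here.

Measured compounds:
compound 1, `c1ccc(CN[C@H]2CC[C@@H](c3c[nH]c4ccccc43)CC2)cc1`, 21%;
compound 2, `c1ccc(CN[C@H]2CC[C@H](c3c[nH]c4ccccc43)CC2)cc1`, 64%;
compound 3, `N#Cc1ccc2[nH]cc(C3=CCC(NCc4ccccc4)CC3)c2c1`, 27%.

In an assay on cell membranes for binding affinity to Adrenergic receptor alpha-1 (Rattus norvegicus), tested at 1 uM (on this read-out higher numbers stand for more inhibition at the one concentration tested (going by the name of the read-out) and lower numbers for less inhibition), compound 1 gives the lowest of the three numbers; compound 3 lies within the scatter of it, while compound 2 stands well apart, with the step of a number 43 percentage points higher from compound 1 to compound 2 (beyond the scatter), the two differing only in configuration (the fact that compounds 1 and 2 differ only in the configuration as drawn). The unmeasured compound 4, `N#Cc1ccc2[nH]cc([C@H]3CC[C@@H](NCc4ccccc4)CC3)c2c1`, keeps the configuration of compound 1 and differs from it by cyano in place of hydrogen on an aromatic carbon. Among the measured compounds shown here, no measured step involves this change; the only measured step concerns configuration, not this substituent, and compound 3, which carries the same cyano group on a different core, sits within the scatter of compound 1. The step of a number 4 percentage points higher from compound 1 to compound 4 (within the scatter) is therefore expected to stay small. For compound 4 the estimate in this assay is 25%, within 8% to 50%.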

Compound 4, a percentage reported as inhibition, at one concentration (the size of the read-out at that concentration, not a potency): 17%
Compound 4: the middle estimate sits 8 percentage points above what was measured; measured number inside the range.
By their numbers in this assay, from the lowest: compounds 4, 1 and 3 (each within the scatter of the next); then compound 2.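

With the configuration of compound 1 kept, cyano in place of hydrogen on an aromatic carbon gives a number 4 percentage points lower from compound 1 to compound 4 (within the scatter) in this assay and so, at this position, the two compounds cannot be told apart. Among the compounds shown here, this is the first direct reading of the substituent, as the earlier step concerned configuration alone. Nothing available explains the result of this change.

From the compounds shown here alone, whether cyano would do the same in the configuration of compound 2 remains open. So does whether a carboxylic acid or an amine at this aromatic carbon would shift the number.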